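A few compounds are considered here, and "the series" means these few. Any claim that something is new, unique, unknown or untested is made for them only; others in the source may bear on it.

Of the compounds shown here, three sharing one core have been measured so far in a physicochemical assay for lipophilicity, read by HPLC, at pH 7.5 (a lower number here means a more polar compound, a higher number a more lipophilic compound), on this series. Compound 1 (`CC[C@@H](Nc1c(C#N)c(-c2ccc(-c3ncccc3C)cc2)nc2cnccc12)C(N)=O`) stands at 2 on that scale, and compound 2 (`CC[C@@H](Nc1c(C#N)c(-c2ccc(-c3ccncc3C)cc2)nc2cnccc12)C(N)=O`) stands at 2 on it too, so the pair shows no change at the digits printed from compound 1 to compound 2 (within the scatter) when one methylpyridinyl group is exchanged for another. Compound 3 (`CC[C@@H](Nc1c(C#N)c(-c2ccc(-c3ccccc3C)cc2)nc2cnccc12)C(N)=O`) has the highest number of the three, at 3 on the same scale. It carries 2-methylphenyl in that place, and the two steps that reach it are a number 1.00 log units higher from compound 1 to compound 3 (beyond the scatter) and a number 1.00 log units higher from compound 2 to compound 3 (beyond the scatter), both modest.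

The next compound, compound 4 (`CC[C@@H](Nc1c(C#N)c(-c2ccc(-c3ccccc3C(F)(F)F)cc2)nc2cnccc12)C(N)=O`), differs from compound 3 in one group only: trifluoromethyl in place of methyl on an aromatic carbon, ortho to a large group (trifluoromethyl in place of methyl on an aromatic carbon). Within the data shown here, none of the measured steps touches this methyl, so the data give no direct size for the exchange. The step of a number 1.00 log units higher from compound 2 to compound 3 (beyond the scatter) is the only scale available, and a smaller move than that seems likely. An upward move is expected, estimated as a number 0.40 log units higher from compound 3 to compound 4 (beyond the scatter) and still uncertain. Compound 4 is therefore expected at 3.4 with an estimated range from 2.9 to 4 on that scale.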

Compound 4, distribution coefficient: 3.1
The estimate for compound 4 lay 0.30 log units above the measured number; the measured number falls inside the stated range.
By their numbers in this assay, from the lowest: compounds 1 and 2 (each within the scatter of the next); then compounds 3 and 4 (each within the scatter of the next).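

In this assay, trifluoromethyl in place of methyl on an aromatic carbon, ortho to a large group, gives a number 0.10 log units higher from compound 3 to compound 4 (within the scatter), so this exchange, although it brings in more heavy atoms, does not separate the two compounds at this position. The larger difference among these compounds still lies in the ring itself: a number 1.10 log units higher from compound 2 to compound 4 (beyond the scatter) and a number 1.10 log units higher from compound 1 to compound 4 (beyond the scatter), and both of these steps are of a similar size to a number 1.00 log units higher from compound 2 to compound 3 (beyond the scatter) and a number 1.00 log units higher from compound 1 to compound 3 (beyond the scatter), which lead to the methyl-bearing phenyl compound. So the four compounds fall into two groups, with the two methylpyridinyl compounds at the lower end and the two substituted phenyl compounds at the upper end, and none of the four goes against this split, though no measurement shown here gives a reason for it.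

Going by these compounds, what remains open is whether the same exchange would also leave the number in place on a pyridine ring, as in 3-(trifluoromethyl)pyridin-2-yl. On these data alone, it is also open how far the number would move with a group of another kind in this place, such as an amine or a carboxylic acid, on the 2-substituted phenyl ring.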